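Adding chloro to the phenyl of compound 2

The compounds below may be only part of what the source reports. "The series", "measured", "known", "first", "only" and "open" are said of these compounds alone.

Of the compounds shown here, two sharing one core have numbers so far. In a functional assay on HT-29 cells (Homo sapiens) for antiproliferative activity, read by MTT assay, with a stated time of 24 h (a higher number here means a weaker inhibitor, a lower number a stronger inhibitor), compound 1 `COc1ccc(C(=O)/C=C/c2ccc(N(C)C)cc2)c2c1C=CC(C)(C)O2`, which carries a dimethylamino group, gives 1870 nM. Compound 2 `COc1ccc(C(=O)/C=C/c2ccccc2)c2c1C=CC(C)(C)O2`, with hydrogen in that place, gives > 10000 nM, which is a limit of the assay and not a number. For the measured compounds named here, the one measured step, an at least 5.3-fold higher number from compound 1 to compound 2 (0.72 log units; beyond the scatter), lies beyond the scatter. Its size is open-ended.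

Compound 3 `COc1ccc(C(=O)/C=C/c2ccc(Cl)cc2)c2c1C=CC(C)(C)O2` keeps the core of compound 2 and changes one place: chloro in place of hydrogen on an aromatic carbon. This is chloro in place of hydrogen on an aromatic carbon, para to a large group, so phenyl becomes 4-chlorophenyl. Going by the values given here, the only guide is the step from dimethylamino to hydrogen, and it concerns a different group, so it guides only loosely. Still, compound 1 at 1870 nM shows that a group in this place can go with a lower number, so a modest move toward a lower number in this assay is expected. The expected step is an at least 2.2-fold lower number from compound 2 to compound 3 (0.34 log units; beyond the scatter). For compound 3 the estimated value is 4500 nM, with an expected range from 2000 nM to 10000 nM.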

Compound 3, half-maximal inhibitory concentration: > 10000 nM
Compound 3 gave a limit, no number; the forecaster's own chance of this, stated with the estimate: 35%; middle value at least 2.2-fold (0.34 log units) away from the limit.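

In this assay compound 3, like compound 2, carries a limit and not a number, so putting chloro on this aromatic carbon, turning phenyl into 4-chlorophenyl, does not yield a readable value. Chloro in place of dimethylamino gives an at least 5.3-fold higher number from compound 1 to compound 3 (0.72 log units; beyond the scatter), which shows that the readable value of compound 1 does not come with just any group in this place: of the two groups tried here, only dimethylamino goes with a number. The step between compound 2 and compound 3 cannot be read, because both compounds sit at the same limit: the limit of > 10000 nM in this assay, at which 2 of the 3 values shown sit.

As far as these compounds go, whether chloro changes activity at all remains open, as does how far compound 3 actually lies from compound 2 and from compound 1. From the compounds shown here alone, it is also open whether the number seen for compound 1 is tied to dimethylamino itself or would also appear with another nitrogen group in the same place, such as a plain amine or a pyrrolidine ring, and a carboxylic acid there would test the same question with a group that has no such nitrogen.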